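A few compounds are considered here, and "the series" means these few. Any claim that something is new, unique, unknown or untested is made for them only; others in the source may bear on it.

Measured so far:
compound 1 `CCCCCCOc1cccc(O)c1C(=O)/C=C/c1ccc(O)cc1` — in a functional assay on HCT-15 cells (Homo sapiens) for antiproliferative activity, read by sulforhodamine B assay (a lower number here means a stronger inhibitor of growth, a higher number a weaker inhibitor of growth), compound 1 gives > 30000 nM
compound 2 `CCC(CC)COc1cccc(O)c1C(=O)/C=C/c1ccc(O)cc1` — in this assay compound 2 gives 3420 nM

Compound 1 stands only at a limit of this assay; its value > 30000 nM is a limit and not a number, as the limit of > 30000 nM in this assay, at which 1 of the 2 values shown sits, notes. Compound 3 `O=C(/C=C/c1ccc(O)cc1)c1c(O)cccc1OCCC1CCCC1` has not yet been measured. It differs from compound 1 by cyclopentyl in place of butyl on a saturated chain carbon, two bonds along the chain from an oxygen on an aromatic ring. For the measured compounds named here, the one measured step that bears on this change is an at least 8.7-fold lower number from compound 1 to compound 2 (0.94 log units; beyond the scatter), where a branched chain replaced a straight one at the oxygen on the aromatic ring. Compound 3 likewise trades the straight hexyl chain for a bulkier, ring-bearing chain, though the branching sits further out. A lower number is therefore expected in this assay for compound 3, though of uncertain size. The expected step is an at least 3.0-fold lower number from compound 1 to compound 3 (0.47 log units; beyond the scatter). Compound 3 is estimated at 10000 nM, with a range from 2500 nM to 40000 nM.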

Compound 3, concentration for 50% growth inhibition: 3310 nM
Beside the measured number, compound 3's estimate is 3.0-fold (0.48 log units) above it; low and high end bracket the measured number.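

In this assay the gain over the straight hexyl chain is not confined to the branched chain of compound 2: a chain ending in a cyclopentyl ring also gives an at least 9.0-fold lower number from compound 1 to compound 3 (0.95 log units; beyond the scatter) on the same core. Compared with compound 2, the ring-bearing chain gives a 1.0-fold lower number from compound 2 to compound 3 (0.01 log units; within the scatter) and so cannot be told apart from the branched chain in this read-out. The size of the first step rests on compound 1, whose value is a limit and not a number: the limit of > 30000 nM in this assay, at which 1 of the 3 values shown sits.

The compounds shown leave open whether a cyclohexyl ring, a phenyl ring or a longer chain ending in a ring would hold growth inhibition at this level. They also leave open what an amine or a carboxylic acid at the end of the chain would do.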